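The source may report more compounds than this note shows. Statements on the series, on what has been measured and on what is new or still open speak of the compounds shown alone.

Compound 2 `COc1nc(-c2ccsc2)ccc1[C@@H](c1ccccc1)[C@@](O)(CCN(C)C)c1cccc2ccccc12` gives 24.4 ug/mL in a toxicity assay on Vero cells (Chlorocebus sabaeus) for cytotoxicity; on this read-out lower numbers stand for higher toxicity in this test and higher numbers for lower toxicity in this test. Compound 1 `COc1nc(C(C)(C)C)ccc1[C@@H](c1ccccc1)[C@@](O)(CCN(C)C)c1cccc2ccccc12` gives 27.6 ug/mL in this assay, and the step of a 1.1-fold lower number from compound 1 to compound 2 (0.05 log units; within the scatter) stays within the scatter. Compound 3 `COc1nc(-c2ccc(Cl)cc2)ccc1[C@@H](c1ccccc1)[C@@](O)(CCN(C)C)c1cccc2ccccc12` reaches only a limit of this assay, reported as > 50 ug/mL. Among the numbers shown, compound 2 has the lowest, with compound 1 nearest. Compound 4 `COc1nc(-c2cnsc2)ccc1[C@@H](c1ccccc1)[C@@](O)(CCN(C)C)c1cccc2ccccc12` differs from compound 2 by 1,2-thiazol-4-yl in place of thiophen-3-yl on an aromatic carbon. The measured steps of a 1.1-fold lower number from compound 1 to compound 2 (0.05 log units; within the scatter) and an at least 2.0-fold higher number from compound 2 to compound 3 (0.31 log units; beyond the scatter) concern other groups at the same place; here one five-membered aromatic ring with 1 hetero atom gives way to one with 2 hetero atoms. Little movement in this assay is therefore expected: for compound 4 an estimated 1.1-fold higher number from compound 2 to compound 4 (0.03 log units; within the scatter), giving 26 ug/mL with a range from 15 ug/mL to 45 ug/mL.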

Compound 4, half-maximal cytotoxic concentration: 26.3 ug/mL
Compound 4: the middle estimate sits 1.0-fold (0.00 log units) below what was measured; low and high end bracket the measured number.
By their numbers in this assay, from the lowest: compounds 2, 4 and 1 (each within the scatter of the next). At a limit, above all of these: compound 3.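

At this position, a second hetero atom in the five-membered aromatic ring leaves this assay essentially unchanged: a 1.1-fold higher number from compound 2 to compound 4 (0.03 log units; within the scatter). The comparison with tert-butyl also shows no separation, with a 1.0-fold lower number from compound 1 to compound 4 (0.02 log units; within the scatter), so these three groups cannot be told apart here. Against the 4-chlorophenyl group only a floor can be read, an at least 1.9-fold lower number from compound 3 to compound 4 (0.27 log units; that floor lies within the scatter), and compound 3 remains a limit rather than a number: the limit of > 50 ug/mL in this assay, at which 1 of the 4 values shown sits.

As far as these compounds go, how far the 4-chlorophenyl group truly lies from 1,2-thiazol-4-yl remains open. So does what an amine or a carboxylic acid at this position would do to the number.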